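This account rests on a few compounds, and the source may have more. Where it says the series, first, only, none or still open, it means among the compounds named here.

Compound 1 `COc1ccc(N/N=C2\CCC(C)n3c2ncc(C(=O)O)c3=O)cc1` gives 128000 nM
Compound 2 `CC(=O)c1ccc(N/N=C2\CCC(C)n3c2ncc(C(=O)O)c3=O)cc1` gives 8100 nM
Compound 3 `CC1CC/C(=N\Nc2ccc(C(=O)O)cc2)c2ncc(C(=O)O)c(=O)n21` gives 1000000 nM

These values come from a functional assay (mast cells) for inhibition, with Rattus norvegicus as the target (on this read-out higher numbers stand for an effect only at larger amounts of compound and lower numbers for an effect already at smaller amounts), and the three compounds differ in a single group on an aromatic carbon. Compound 3, which carries the carboxy group, has the highest number of the three, so it needs the largest amount to show an effect.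

Compound 4 `CNC(=O)c1ccc(N/N=C2\CCC(C)n3c2ncc(C(=O)O)c3=O)cc1` has methylamino in place of hydroxy on a carbonyl carbon. The same difference can be read as carboxy to methylcarbamoyl.

Among the compounds with values here, two measured steps bear on this change. The closer one swaps a group on the same carbonyl carbon and is large: a 120-fold higher number from compound 2 to compound 3 (2.09 log units; beyond the scatter). The other starts from methoxy and is modest: a 7.8-fold higher number from compound 1 to compound 3 (0.89 log units; beyond the scatter). In both, arriving at the carboxy group came with a higher number. Compound 4 also lacks the carboxy group, so a step to a lower number is expected in this assay, probably a large one. Within the data shown here, no measured compound carries methylamino on this carbonyl carbon, so the size remains uncertain. The expected change is a 50-fold lower number from compound 3 to compound 4 (1.70 log units; beyond the scatter). For compound 4 the estimated value is 20000 nM, with an expected range from 4000 nM to 120000 nM.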

Compound 4, half-maximal effective concentration: 100000 nM
For compound 4 the middle estimate is 5.0-fold (0.70 log units) below the measured one; low and high end bracket the measured number.
By their numbers in this assay, from the lowest: compound 2; then compounds 4 and 1 (each within the scatter of the next); then compound 3.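

In this assay methylamino in place of hydroxy on this carbonyl carbon gives a 10-fold lower number from compound 3 to compound 4 (1.00 log units; beyond the scatter) and so shows that the carboxy group can be replaced with a clear gain, but methylamino in place of methyl on the same carbon still gives a 12-fold higher number from compound 2 to compound 4 (1.09 log units; beyond the scatter) and so recovers only part of what the acetyl group offers. Set against methoxy on the aromatic carbon, methylcarbamoyl gives a 1.3-fold lower number from compound 1 to compound 4 (0.11 log units; within the scatter) and the two groups cannot be told apart here, while compound 2 with its acetyl group keeps a clearly lower number than each of the other three compounds. Nothing available explains why these groups on the aromatic carbon give such different numbers.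

The compounds shown leave open whether a plain amino group on this carbonyl carbon, or a longer chain such as ethylamino, would move the number toward that of compound 2 or toward that of compound 3. They also leave open how a methyl ester or a nitrile on the aromatic carbon would compare with the acetyl group.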